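Ring Size on the Amide of the Benzylic Side Chain

This account rests on a few compounds, and the source may have more. Where it says the series, first, only, none or still open, it means among the compounds named here.

The series shares a core carrying an arylsulfonamide and a benzyl group whose side chain ends in an amide. In a functional assay on CHO cells for antagonist activity at C-C chemokine receptor type 4 (Homo sapiens), read by GTPgammaS binding (a higher number here means a weaker inhibitor, a lower number a stronger inhibitor), compound 1 `CC(=O)NCc1cccc(Cn2nc(NS(=O)(=O)c3ccc(Cl)s3)c3c(C(C)O)cccc32)c1` gives 20 nM, and compound 2 `CC(=O)NCc1cccc(Cn2nc(NS(=O)(=O)c3ccc(Cl)s3)c3c(C(C)(C)O)cccc32)c1` gives 100 nM; the step from one to the other is a 5.0-fold higher number from compound 1 to compound 2 (0.70 log units; beyond the scatter). Compound 3 `COc1cccc2c1c(NS(=O)(=O)c1ccc(Cl)s1)nn2Cc1cccc(CNC(=O)C2CCO2)c1` gives 31.6 nM in this assay, which puts it second highest of the three numbers: nearest to compound 1 and within the scatter of it, but beyond the scatter from compound 2, which sits higher. Compound 1 and compound 3 differ in two places, so their values are compared only as they stand.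

Compound 4 `COc1cccc2c1c(NS(=O)(=O)c1ccc(Cl)s1)nn2Cc1cccc(CNC(=O)C2CCOCC2)c1` differs from compound 3 by oxan-4-yl in place of oxetan-2-yl on a carbonyl carbon. Going by the values given here, no measured step touches that part of the molecule; the single step from compound 1 to compound 2 concerns a carbon bound to the core and says nothing about the amide substituent. Among the compounds with values here, with no direct precedent, the change in this assay is expected to stay small, with the expected step of a 1.3-fold higher number from compound 3 to compound 4 (0.10 log units; within the scatter) kept within, or only just beyond, the scatter. Compound 4 is therefore estimated at 40 nM in this assay, in the range 15 nM to 120 nM.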

Compound 4, half-maximal inhibitory concentration: 31.6 nM
The estimate for compound 4 lay 1.3-fold (0.10 log units) above the measured number; low and high end bracket the measured number.
By their numbers in this assay, from the lowest: compounds 1, 3 and 4 (each within the scatter of the next); then compound 2.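

In this assay, the amide substituent now has its first direct reading: oxan-4-yl in place of oxetan-2-yl on a carbonyl carbon leaves the number unchanged (no change at the digits printed from compound 3 to compound 4 (within the scatter)). Going by these compounds alone, this change takes a four-membered non-aromatic ring of 4 heavy atoms to a six-membered one of 6 heavy atoms, each with 1 hetero atom and 1 hydrogen-bond acceptor, so for this pair the larger ring costs nothing measurable, whereas the only earlier step, at the carbon bound to the core, was beyond the scatter (a 5.0-fold higher number from compound 1 to compound 2 (0.70 log units; beyond the scatter)). Nothing available explains why the number holds across this change.

The compounds shown leave open whether this flat reading depends on the ring oxygen, since neither a piperidin-4-yl ring with a nitrogen in its place nor an all-carbon cyclohexyl ring appears among them. They also leave open whether an open chain such as a methoxyethyl group on the same carbonyl carbon would read the same, and whether the result would carry over to compound 1, whose amide ends in a methyl group and whose core substituent differs.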